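This account rests on a few compounds, and the source may have more. Where it says the series, first, only, none or still open, it means among the compounds named here.

Measured compounds:
- compound 1 `O=C(Nc1cccc(-c2oc3cc(-c4ccc(F)cc4)ccc3c(=O)c2O)c1)c1ccc(F)cc1F`: 11200 nM
- compound 2 `Cc1ccccc1C(=O)Nc1cccc(-c2oc3cc(-c4ccc(F)cc4)ccc3c(=O)c2O)c1`: 4910 nM
- compound 3 `Cc1cc(C(=O)Nc2cccc(-c3oc4cc(-c5ccc(F)cc5)ccc4c(=O)c3O)c2)ccc1F`: 7440 nM

These three compounds share one core and differ only in the aryl group attached to the carbonyl carbon of the amide. In a functional assay on MDA-MB-231 cells (Homo sapiens) for antiproliferative activity, read by CCK-8 assay, with a stated time of 72 h (a higher number here means a weaker inhibitor, a lower number a stronger inhibitor), compound 2 gives the lowest number of the three. Its nearest neighbour is compound 3, and the step of a 1.5-fold higher number from compound 2 to compound 3 (0.18 log units; within the scatter) lies within the scatter, so the two cannot be ordered. The step of a 2.3-fold lower number from compound 1 to compound 2 (0.36 log units; beyond the scatter) is the only one beyond the scatter, and the step of a 1.5-fold lower number from compound 1 to compound 3 (0.18 log units; within the scatter) is within it.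

Compound 4 `COc1cc(OC)cc(C(=O)Nc2cccc(-c3oc4cc(-c5ccc(F)cc5)ccc4c(=O)c3O)c2)c1` is not yet measured. It differs from compound 2 in one place: 3,5-dimethoxyphenyl in place of 2-methylphenyl on a carbonyl carbon

The measured steps bear on this change only loosely: each swaps the aryl group on the same carbonyl carbon, and none moved the number by more than a modest amount. For the measured compounds named here, no measured compound carries a methoxy group, so the direction is uncertain. A step of similar size, if any, is expected, most likely a 1.4-fold higher number from compound 2 to compound 4 (0.15 log units; within the scatter) toward a somewhat higher number. Compound 4 is therefore estimated at 7000 nM, with a range from 3000 nM to 16000 nM.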

Compound 4, half-maximal inhibitory concentration: 4040 nM
Compound 4: the middle estimate sits 1.7-fold (0.24 log units) above what was measured; the measured number falls inside the stated range.
By their numbers in this assay, from the lowest: compounds 4, 2, 3 and 1 (each within the scatter of the next, the first and the last beyond it).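

In this assay, for the compounds shown here, the 3,5-dimethoxyphenyl group puts oxygen atoms and hydrogen-bond acceptors on this aryl ring for the first time, yet the step of a 1.2-fold lower number from compound 2 to compound 4 (0.08 log units; within the scatter) and the step of a 1.8-fold lower number from compound 3 to compound 4 (0.27 log units; within the scatter) both stay within the scatter, so compound 4 cannot be ordered against compound 2 or compound 3. The step of a 2.8-fold lower number from compound 1 to compound 4 (0.44 log units; beyond the scatter) is beyond the scatter, so compound 1 with its 2,4-difluorophenyl group now separates from both compound 2 and compound 4, though not from compound 3, which goes against any clean split. Nothing available explains these numbers.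

Open, on these data alone, is whether an amine or a carboxylic acid on this aryl ring, or a longer chain in its place, would shift the number further. Also open, as far as these compounds go, is how a phenyl carrying a single methoxy group would compare with the 3,5-dimethoxyphenyl group.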